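The source may hold more compounds than are shown below. What is called first, only, known or untested is meant among the compounds shown, and "the series" means these compounds.

Compound 1, `O=c1ccoc2cc(OCc3cn(Cc4ccccc4)nn3)ccc12`: in a functional assay on HeLa cells (Homo sapiens) for cytotoxicity, read by MTT assay, with a stated time of 48 h (a lower number here means a stronger inhibitor, a higher number a weaker inhibitor), compound 1 reaches only a limit of the assay, > 100000 nM.
Compound 2, `O=c1ccoc2cc(OCc3cn(Cc4cccc(F)c4)nn3)ccc12`: in this assay compound 2 gives 7550 nM.
Compound 3, `O=c1ccoc2cc(OCc3cn(Cc4ccc(F)cc4)nn3)ccc12`: in this assay compound 3 gives 12000 nM.

Compound 3 holds the highest of the two actual numbers; compound 2 sits nearest, and the difference between them, a 1.6-fold higher number from compound 2 to compound 3 (0.20 log units; within the scatter), stays within the scatter. The limit of compound 1 is set out as the limit of > 100000 nM in this assay, at which 1 of the 3 values shown sits.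

Compound 4, `O=c1ccoc2cc(OCc3cn(Cc4cccc([N+](=O)[O-])c4)nn3)ccc12`, has not been measured in this assay. It differs from compound 3 by 3-nitrophenyl in place of 4-fluorophenyl on a saturated chain carbon bound to an aromatic nitrogen. Two kinds of measured step bear on this. Moving the fluorine between positions on the phenyl ring, a 1.6-fold higher number from compound 2 to compound 3 (0.20 log units; within the scatter), changed little. Introducing a substituent onto the unsubstituted phenyl ring of compound 1, however, gave an at least 13-fold lower number from compound 1 to compound 2 (1.12 log units; beyond the scatter) and an at least 8.3-fold lower number from compound 1 to compound 3 (0.92 log units; beyond the scatter). Among the compounds with values here, no measured step replaces a fluoro group with a nitro group, so the data support only a cautious expectation. Compound 4 is expected to give roughly 7000 nM, between 1500 nM and 35000 nM, which means an expected step of a 1.7-fold lower number from compound 3 to compound 4 (0.23 log units; within the scatter).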

Compound 4, half-maximal inhibitory concentration: 17300 nM
Compound 4: the middle estimate sits 2.5-fold (0.39 log units) below what was measured, within the range that was stated.
By their numbers in this assay, from the lowest: compounds 2, 3 and 4 (each within the scatter of the next, the first and the last beyond it). At a limit, above all of these: compound 1.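

At this place, on a saturated chain carbon bound to an aromatic nitrogen, 3-nitrophenyl and 4-fluorophenyl cannot be told apart in this assay (a 1.4-fold higher number from compound 3 to compound 4 (0.16 log units; within the scatter)), whereas nitro in place of fluoro on an aromatic carbon gives a modest step beyond the scatter (a 2.3-fold higher number from compound 2 to compound 4 (0.36 log units; beyond the scatter)). The drop from the unsubstituted phenyl ring is also not confined to fluoro, since nitro in place of hydrogen gives a step of its own (an at least 5.7-fold lower number from compound 1 to compound 4 (0.76 log units; beyond the scatter)). On these data alone, the size of that step remains open-ended, as compound 1 stands only at a limit: the limit of > 100000 nM in this assay, at which 1 of the 4 values shown sits. The compounds shown leave open whether other groups on the phenyl ring, such as an amine or a carboxylic acid, would give numbers like these. They also leave open what a longer chain in place of the phenyl ring would give.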